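Working notes: cytotoxicity of compound 1 and its analogues

The source may report more compounds than this note shows. Statements on the series, on what has been measured and on what is new or still open speak of the compounds shown alone.

Measured so far:
compound 1 `O=C(NCc1ccc(F)cc1)c1cccc(O)c1O`: > 40000 nM
compound 2 `O=C(NCc1ccc(F)cc1)c1cccc(OCc2ccccc2)c1O`: > 40000 nM
compound 3 `CNC(=O)c1cc(F)ccc1CNC(=O)c1cccc(O)c1O`: > 40000 nM

In an ADME assay on NCI-H630 cells (Homo sapiens) for cytotoxicity, read by MTT assay, with a stated time of 72 h (on this read-out higher numbers stand for lower toxicity in this test and lower numbers for higher toxicity in this test), compound 1 gives > 40000 nM, which is a limit of the assay and not a number. Compound 2 likewise returns only a limit in this assay. Compound 3 also returns only a limit in this assay. Consequently the step that the two limits leave unreadable from compound 1 to compound 2 cannot be sized, and the same holds for a step that the two limits leave unreadable from compound 1 to compound 3; the evidence so far is simply (the limit of > 40000 nM in this assay, at which 3 of the 3 values shown sit).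

Compound 4 `CNS(=O)(=O)c1cc(O)c(O)c(C(=O)NCc2ccc(F)cc2)c1` differs from compound 1 by methylsulfamoyl in place of hydrogen on an aromatic carbon. Among the measured compounds shown here, neither measured step bears readably on this change, since both start and end at the limit, so no direction can be derived from them; nothing among the measured compounds shows a move away from the limit in this assay. It is therefore expected that compound 4 also sits at the limit, with the estimated step that the limit leaves unreadable from compound 1 to compound 4 being unreadable in practice. The estimate for compound 4 in this assay is 60000 nM, expected to lie between 25000 nM and 200000 nM.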

Compound 4, half-maximal cytotoxic concentration: > 40000 nM
Compound 4: no number, only a limit; the forecaster's own chance of this, stated with the estimate: 85%; the middle value is on the limit's open side.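

Among the compounds shown here, compound 4, like compound 1, returns only a limit in this assay, so no step between compound 1 and compound 4 can be read. The compounds shown leave open how far each lies from that limit, and whether any change to the core of compound 1 moves a value off it: the limit of > 40000 nM in this assay, at which 4 of the 4 values shown sit.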